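Replacing a dioxane ring with a short diol on an isoflavone

A few compounds are considered here, and "the series" means these few. Any claim that something is new, unique, unknown or untested is made for them only; others in the source may bear on it.

Measured so far in a functional assay on mitochondria (Cricetulus griseus) for inhibition of Monoamine oxidase (Homo sapiens), tested at 0.3 uM; on this read-out higher numbers stand for a stronger effect at the one concentration tested and lower numbers for a weaker effect:
- compound 1 `CCOc1ccc2c(=O)c(-c3ccc(O)cc3)coc2c1`: 64.8%
- compound 2 `O=c1c(-c2ccc(O)cc2)coc2cc(OCCC3OCCCO3)ccc12`: 41%
- compound 3 `O=C(O)CCCCCCCCCOc1ccc2c(=O)c(-c3ccc(O)cc3)coc2c1`: 74.4%

Compound 2 stands lowest of the three: compound 1 sits above it by a number 23.8 percentage points lower from compound 1 to compound 2 (beyond the scatter) read in reverse, and compound 3 by a number 33.4 percentage points higher from compound 2 to compound 3 (beyond the scatter), both beyond the scatter.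

Compound 4 `O=c1c(-c2ccc(O)cc2)coc2cc(OCC(O)CO)ccc12` is not yet measured. Relative to compound 2, the change is a group of 4 heavy atoms (2 carbon, 2 oxygen; no ring) in place of a group of 7 heavy atoms (5 carbon, 2 oxygen; one six-membered non-aromatic ring with 2 hetero atoms), on a saturated chain carbon bound to an oxygen on an aromatic ring.

For the measured compounds named here, the steps that bear on this are the two that remove or install the same ring-bearing group: a number 23.8 percentage points lower from compound 1 to compound 2 (beyond the scatter) and a number 33.4 percentage points higher from compound 2 to compound 3 (beyond the scatter). Taking the ring away has twice gone with a higher number, so a rise in this assay is expected, though the new group is smaller than either comparison. For compound 4 a step of a number 15 percentage points higher from compound 2 to compound 4 (beyond the scatter) is expected, giving an estimated 56% with a range from 36% to 76%.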

Compound 4, a percentage reported as inhibition, at one concentration (the size of the read-out at that concentration, not a potency): 33.3%
Compound 4: middle estimate off by 22.7 percentage points, on the high side, and the stated range ends above it.
By their numbers in this assay, from the lowest: compounds 4 and 2 (each within the scatter of the next); then compounds 1 and 3 (each within the scatter of the next).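

In this assay, replacing the ring-bearing group with 1,2-dihydroxyethyl gives a number 7.7 percentage points lower from compound 2 to compound 4 (within the scatter) and so does not lift the number back towards compound 1. Set against the methyl of compound 1, the same 1,2-dihydroxyethyl gives a number 31.5 percentage points lower from compound 1 to compound 4 (beyond the scatter) and shows that a short chain without the ring can still lose much of the effect at this position. Nothing measured here gives a reason for either step. Going by these compounds, whether an amine in place of 1,2-dihydroxyethyl would read like compound 1 or like compound 4 remains open.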